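The source may report more compounds than this note shows. Statements on the series, on what has been measured and on what is new or still open speak of the compounds shown alone.

Working notes on the series.

Three compounds carry numbers in a functional assay on the whole organism (Tail, strain ICR) with Mus musculus as the target, in the tail flick test, with a stated time of 150 min, at a dose of 25 umol/kg by the oral route; on this read-out lower numbers stand for a weaker effect and higher numbers for a stronger effect at the one dose given. Compound 1, `O=C(CN(c1nc(Cl)nc2[nH]cnc12)C1CC1)N[C@@H](CO)C(=O)OCc1ccccc1`, gives 27.9% in this assay, the highest of the three. Compound 3, `O=C(CN(c1ncnc2c1ncn2C1CCCCO1)C1CC1)NCC(=O)OCc1ccccc1`, gives 7.26% in this assay and is the nearest to compound 1, yet still beyond the scatter below it. Compound 2, `N=C(N)NCCC[C@H](NC(=O)CN(c1nc(Cl)nc2[nH]cnc12)C1CC1)C(=O)O`, gives 7.19% in this assay and is the furthest from compound 1, also beyond the scatter. Among the measured compounds shown here, no pair of measured compounds differs in one place only, so no single step is available to lean on.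

Compound 4, `O=C(CN(c1nc(Cl)nc2[nH]cnc12)C1CC1)N[C@@H](CC(=O)OCc1ccccc1)C(=O)OCc1ccccc1`, is not yet measured. It differs from compound 1 as follows: benzyloxycarbonyl in place of hydroxy on a saturated chain carbon, two bonds along the chain from an amide-type nitrogen and a carbonyl carbon. For the measured compounds named here, with no comparable step among the measured compounds, the expected step from compound 1 to compound 4 in this assay is estimated as small, a number 7.9 percentage points lower from compound 1 to compound 4 (within the scatter), most likely within the scatter or slightly downward. For compound 4 the expected value in this assay is estimated at 20%, with a range from 5% to 40%.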

Compound 4, a percentage reported as activity, at one dose (the size of the read-out at that dose, not a potency): 6.68%
Compound 4: the middle estimate sits 13.3 percentage points above what was measured, within the range that was stated.
By their numbers in this assay, from the lowest: compounds 4, 2 and 3 (each within the scatter of the next); then compound 1.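

Among the compounds shown here, this pair gives the first single-place comparison in this assay: benzyloxycarbonyl in place of hydroxy, on a saturated chain carbon, two bonds along the chain from an amide-type nitrogen and a carbonyl carbon, gives a number 21.2 percentage points lower from compound 1 to compound 4 (beyond the scatter). The read-out at this dose therefore depends on what this position carries, and hydroxymethyl cannot be exchanged for (benzyloxycarbonyl)methyl without losing most of the effect seen with compound 1, though this rests on one pair and sets no pattern. No evidence on hand accounts for the drop.

The compounds shown cannot separate the departure of hydroxy from the arrival of benzyloxycarbonyl. A methyl, a methoxy or a carboxylic acid at this carbon would tell these two apart, and a longer chain carrying hydroxy would test how far the position stretches.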